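This account rests on a few compounds, and the source may have more. Where it says the series, first, only, none or still open, it means among the compounds named here.

Two compounds share a core in which a cyanoguanidine is joined to a propyl chain ending in an aryl ether that carries a piperidinylmethyl group; they differ only in the chain and acyl group on the other side of the cyanoguanidine. In a functional assay on cardiac atrium for antagonist activity at histamine H2 receptor (Cavia porcellus) (a higher number here means a more potent compound, by a factor of ten per unit of this negative logarithm, a lower number a less potent compound), compound 1 `N#CN/C(=N\CCCCCCNC(=O)c1ccccc1)NCCCOc1cccc(CN2CCCCC2)c1` gives 6.6. Compound 2 `N#CN/C(=N\CCNC(=O)CCc1ccccc1)NCCCOc1cccc(CN2CCCCC2)c1`, measured in this assay, gives 6.27 and so stands lowest of the two numbers, with compound 1 the nearer value and beyond the scatter above it.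

The next compound, compound 3 `N#CN/C(=N\CCCNC(=O)CCc1ccccc1)NCCCOc1cccc(CN2CCCCC2)c1`, is not yet measured. It differs from compound 2 by a single change: ((phenethylcarbonyl)amino)methyl in place of (phenethylcarbonyl)amino on a saturated chain carbon, two bonds along the chain from a double-bonded nitrogen. Among the measured compounds shown here, no step between two measured compounds isolates this kind of chain lengthening, so the expectation rests on the two values alone. The longer chain of compound 1 sits above compound 2, and a modest gain for compound 3 is therefore expected, a step of a number 0.23 log units higher from compound 2 to compound 3 (within the scatter) from compound 2 to compound 3, at or just beyond the scatter. The estimate for compound 3 in this assay is 6.5, with a range from 6 to 7.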

Compound 3, negative logarithm of the antagonist equilibrium constant: 6.07
For compound 3 the middle estimate is 0.43 log units above the measured one; low and high end bracket the measured number.
By their numbers in this assay, from the lowest: compounds 3 and 2 (each within the scatter of the next); then compound 1.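

In this assay, one extra chain carbon, ((phenethylcarbonyl)amino)methyl in place of (phenethylcarbonyl)amino, gives a number 0.20 log units lower from compound 2 to compound 3 (within the scatter), so at this position a lengthening of this size leaves the read-out indistinguishable from that of the shorter compound. Among the compounds shown here, this is the first direct look at chain length with the amide end held constant, and it gives no sign that a single added carbon matters here. The other comparison, (phenethylcarbonyl)amino in place of 3-benzamidopropyl on a saturated chain carbon, three bonds along the chain from a double-bonded nitrogen, gives a number 0.53 log units lower from compound 1 to compound 3 (beyond the scatter), a modest step that does reach beyond the scatter, but it alters chain length and the acyl group together, so it cannot be credited to either one alone.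

A longer chain ending in (phenethylcarbonyl)amino, or a shorter chain ending in a benzamide, would separate those two contributions, and a simple amine or a carboxylic acid at the chain end would test whether the amide is needed at all. Nothing else measured here speaks to why these numbers fall as they do.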